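Cytotoxicity notes on the tertiary benzylamine series

A few compounds are considered here, and "the series" means these few. Any claim that something is new, unique, unknown or untested is made for them only; others in the source may bear on it.

Compound 1 `Cc1ccc2[nH]c(=O)c(CN(Cc3ccc(C(N)=O)cc3)Cc3ccc(C(C)(C)C)cc3)cc2c1` and compound 2 `Cc1ccc2[nH]c(=O)c(CN(Cc3ccc(SC(F)F)cc3)Cc3ccc(C(C)(C)C)cc3)cc2c1` share one core. In a toxicity assay on MDCK cells (Canis lupus familiaris) for cytotoxicity, read by crystal violet staining, with a stated time of 48 h (a higher number here means that more compound is tolerated, a lower number that less compound is tolerated), compound 1 gives only a limit, > 5000 nM. In this assay compound 2 likewise gives only a limit, > 5000 nM. The step that the two limits leave unreadable from compound 1 to compound 2 therefore has no readable size, both values sitting at the limit of > 5000 nM in this assay, at which 2 of the 2 values shown sit. Compound 3 `Cc1ccc2[nH]c(=O)c(CN(Cc3ccc(C(C)(C)C)cc3)C(C)c3ccc(F)cc3)cc2c1` differs from compound 2 by 1-(4-fluorophenyl)ethyl in place of 4-((difluoromethyl)sulfanyl)benzyl on an amine nitrogen. Going by the values given here, no measured step offers a readable size to set against this change. In this assay compound 3 is expected to sit near 8000 nM (range 4000 nM to 20000 nM). The estimated step that the limit leaves unreadable from compound 2 to compound 3 is expected to be none beyond the scatter.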

Compound 3, half-maximal cytotoxic concentration: > 33000 nM
Compound 3: a limit, no number; the forecaster's own chance of this, stated with the estimate: 80%; middle value at least 4.1-fold (0.61 log units) from the limit.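

In this assay compound 3 gives only a limit, > 33000 nM. Going by these compounds alone, no step among compound 1, compound 2 and compound 3 can be read, as all three values are limits. The compounds shown leave open the concentration at which any of them becomes cytotoxic.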